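Replacing a Hydroxymethyl Side Chain with a Pure Hydrocarbon

The source may hold more compounds than are shown below. What is called first, only, known or untested is meant among the compounds shown, and "the series" means these compounds.

Compound 1, `COc1cc(C(c2ccc(O)c(OC)c2)[C@@H](C)[C@@H](C)CO)ccc1O`: > 100000 nM
Compound 2, `CCCCCCCC[C@H](C(C)C)C(c1ccc(O)c(OC)c1)c1ccc(O)c(OC)c1`: 3700 nM
Compound 3, `COC[C@@H](C)[C@@H](C)C(c1ccc(O)c(OC)c1)c1ccc(O)c(OC)c1`: 85000 nM

Of the compounds shown here, three sharing one core have been tested in a functional assay on HL-60 cells (Homo sapiens) for cytotoxicity, read by WST assay, with a stated time of 48 h; on this read-out lower numbers stand for stronger inhibition and higher numbers for weaker inhibition. For compound 1 the result is only a limit, > 100000 nM, so no number is known for it. Compound 3 gives 85000 nM in this assay. Compound 2 gives 3700 nM in this assay.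

Compound 4, `COc1cc(C(c2ccc(O)c(OC)c2)[C@H](CC(C)C)C(C)C)ccc1O`, differs from compound 1 in one place: 1-isopropyl-3-methylbutyl in place of 2-(hydroxymethyl)-1-methylpropyl on a saturated chain carbon bound to two aromatic carbons. Among the measured compounds shown here, the only measured step at this position is an at least 1.1-fold lower number from compound 1 to compound 3 (0.07 log units; that floor lies within the scatter), a change too small to count, and its size is known only from one side because of the limit of > 100000 nM in this assay, at which 1 of the 3 values shown sits. Compound 2 also carries an all-carbon group at this place and sits at a far lower number, but it differs from compound 1 in more than one place, so no single step can be read from it.

On this basis compound 4 is expected to move to a lower number than compound 1, an estimated step of an at least 5.0-fold lower number from compound 1 to compound 4 (0.69 log units; beyond the scatter). The estimate for compound 4 is 20000 nM, expected to lie between 5000 nM and 80000 nM.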

Compound 4, half-maximal inhibitory concentration: 9600 nM
Estimate against measurement, compound 4: 2.1-fold (0.32 log units) above; low and high end bracket the measured number.
By their numbers in this assay, from the lowest: compound 2; then compound 4; then compound 3. At a limit, above all of these: compound 1.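

Putting the all-carbon 1-isopropyl-3-methylbutyl in place of 2-(hydroxymethyl)-1-methylpropyl, on a saturated chain carbon bound to two aromatic carbons, gives in this assay an at least 10-fold lower number from compound 1 to compound 4 (1.01 log units; beyond the scatter), and this size is only a floor: the limit of > 100000 nM in this assay, at which 1 of the 4 values shown sits. The earlier change from the hydroxymethyl to the methoxymethyl side chain stayed within the scatter, whereas removing the oxygen from that side chain altogether gives a clear move, an 8.9-fold lower number from compound 3 to compound 4 (0.95 log units; beyond the scatter). Among the all-carbon side chains, chain length also matters, with isopropyl in place of heptyl, three bonds along the chain from two aromatic carbons, giving a 2.6-fold higher number from compound 2 to compound 4 (0.41 log units; beyond the scatter).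

The compounds shown do not separate the loss of the oxygen from the gain in size, as the entering group has more heavy atoms and no oxygen at the same time. From the compounds shown here alone, it also remains open how an amine or a carboxylic acid would read at this place, and whether a chain longer than heptyl would lower the number further.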